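A few compounds are considered here, and "the series" means these few. Any claim that something is new, unique, unknown or untested is made for them only; others in the source may bear on it.

Compound 1 `CC[S+]([O-])CCCCN=C=S`: in an ADME assay on Vero cells (Chlorocebus sabaeus) for cytotoxicity, read by MTT assay, with a stated time of 72 h (on this read-out lower numbers stand for stronger inhibition and higher numbers for weaker inhibition), compound 1 gives 7900 nM.
Compound 2 `CCCC[S+]([O-])CCCCN=C=S`: in this assay compound 2 gives 5150 nM.

Compound 2 carries the lower of the two numbers shown, with compound 1 nearest and the gap within the scatter. The step from compound 2 to compound 3 `CC(C)C[S+]([O-])CCCCN=C=S` is isopropyl in place of propyl on a saturated chain carbon bound to a sulfur. For the measured compounds named here, the only measured step, a 1.5-fold lower number from compound 1 to compound 2 (0.19 log units; within the scatter), concerns a different change and stays within the scatter, so nothing measured bears directly on the move to isopropyl. No step beyond the scatter is expected in this assay, and the estimated step is a 1.1-fold higher number from compound 2 to compound 3 (0.03 log units; within the scatter). Compound 3 is therefore expected to give 5500 nM, within 2500 nM to 12000 nM.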

Compound 3, half-maximal inhibitory concentration: 4980 nM
Compound 3: middle estimate off by 1.1-fold (0.04 log units), on the high side; the range from low to high includes it.
By their numbers in this assay, from the lowest: compounds 3, 2 and 1 (each within the scatter of the next).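

In this assay, for the compounds shown here, the change from propyl to isopropyl on a saturated chain carbon bound to a sulfur is the first test of branching at this position, and it reads as a 1.0-fold lower number from compound 2 to compound 3 (0.01 log units; within the scatter). The wider comparison, isopropyl in place of methyl, reads as a 1.6-fold lower number from compound 1 to compound 3 (0.20 log units; within the scatter), so neither change at this position moves the number beyond the scatter. No other data bear on this result.

On these data alone, whether a longer chain, a phenyl ring or an amine at this position would give a step beyond the scatter remains open.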